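The compounds below may be only part of what the source reports. "The series", "measured", "known", "first", "only" and "open" are said of these compounds alone.

Series notes, an assay on CHO cells for displacement of a labelled ligand from adenosine receptor A2b (Homo sapiens), read by scintillation counting, with a stated time of 75 min, in the presence of a further agent that is not named here; a higher number here means a weaker inhibitor, a lower number a stronger inhibitor:

- compound 1, `CCCn1c(=O)[nH]c2nc(-c3ccc(S(=O)(=O)N(C)C)cc3)[nH]c2c1=O`, gives 18.6 nM
- compound 2, `CCCn1c(=O)[nH]c2nc(-c3ccc(S(=O)(=O)N4CCN(C)CC4)cc3)[nH]c2c1=O`, gives 48.2 nM
- compound 3, `CCCn1c(=O)[nH]c2nc(-c3ccc(S(=O)(=O)N4CCN(c5cccc(Cl)c5)CC4)cc3)[nH]c2c1=O`, gives 0.342 nM

Compound 3 holds the lowest number of the three, beyond the scatter against both others. The two measured steps run along a different line: a 2.6-fold higher number from compound 1 to compound 2 (0.41 log units; beyond the scatter), a modest change on the sulfonyl side, and then a 140-fold lower number from compound 2 to compound 3 (2.15 log units; beyond the scatter), the large move that brings in the 3-chlorophenyl group on the ring nitrogen.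

Compound 4 is `CCCn1c(=O)[nH]c2nc(-c3ccc(S(=O)(=O)N4CCN(c5cccc(F)c5)CC4)cc3)[nH]c2c1=O`. It differs from compound 3 by fluoro in place of chloro on an aromatic carbon. For the measured compounds named here, no measured pair shows a swap of one halogen for another on that ring, so the step from compound 3 to compound 4 has no direct precedent here. What is known is that the 3-chlorophenyl group itself carries the large gain in a 140-fold lower number from compound 2 to compound 3 (2.15 log units; beyond the scatter); a fluoro in the same place keeps the aryl group and changes only the substituent. The expectation is therefore that most of the gain is retained, with a small to modest loss, estimated as a 2.3-fold higher number from compound 3 to compound 4 (0.37 log units; beyond the scatter). For compound 4 the estimated value in this assay is 0.8 nM, with a range of 0.3 nM to 2.5 nM.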

Compound 4, inhibition constant: 0.632 nM
Compound 4: the middle estimate sits 1.3-fold (0.10 log units) above what was measured; measured number inside the range.
By their numbers in this assay, from the lowest: compounds 3 and 4 (each within the scatter of the next); then compound 1; then compound 2.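

In this assay, the swap of halogen at this place on the aromatic ring gives a 1.8-fold higher number from compound 3 to compound 4 (0.27 log units; within the scatter), so chloro and fluoro cannot be told apart here, and the two values should be treated as one level. The large gain over the methyl-bearing compound 2 therefore does not depend on chloro alone: the 3-fluorophenyl group also gives a 76-fold lower number from compound 2 to compound 4 (1.88 log units; beyond the scatter), and this second large step shows that the gain seen with the 3-chlorophenyl group carries over to another halogen in the same place. No measurement shown here bears on what lies behind either step.

The compounds shown leave open whether a halogen is needed at all, since plain phenyl and a 3-methoxyphenyl or 3-cyanophenyl group on the same ring nitrogen would separate the part played by the aryl group from that of its substituent. Going by these compounds, it also remains open whether bromo at this place stays at the same level as chloro and fluoro, and whether either halogen would hold that level at another place on the ring.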